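The compounds below may be only part of what the source reports. "The series", "measured", "known", "first", "only" and "open" are said of these compounds alone.

Measured so far:
compound 1 `COc1cc2ncnc(Nc3ccc(F)c(Cl)c3)c2cc1OCCn1ccnc1[N+](=O)[O-]`, > 50000 nM
compound 2 `COc1cc2ncnc(Nc3ccc(OCc4cccc(F)c4)c(Cl)c3)c2cc1OCCCn1ccnc1[N+](=O)[O-]`, 15500 nM

In a functional assay on HT-29 cells (Homo sapiens) for cytotoxicity, read by sulforhodamine B assay, with a stated time of 72 h (on this read-out lower numbers stand for stronger inhibition and higher numbers for weaker inhibition), compound 1 gives > 50000 nM, which is a limit of the assay rather than a number. Compound 1 thus stands at the limit of > 50000 nM in this assay, at which 1 of the 2 values shown sits. Compound 2 differs from compound 1 in more than one place. In this assay compound 2 gives 15500 nM. Compound 1 has only a limit in this assay, so the two values show no more than that compound 2 yields a number where compound 1 does not. Compound 3 `COc1cc2ncnc(Nc3ccc(F)c(Cl)c3)c2cc1OCCCn1c([N+](=O)[O-])cnc1C` has not been measured yet. It differs from compound 1 in one place: (2-methyl-5-nitro-1H-imidazol-1-yl)methyl in place of 2-nitro-1H-imidazol-1-yl on a saturated chain carbon, two bonds along the chain from an oxygen on an aromatic ring. No measured step of this kind exists among these compounds, so the step from compound 1 to compound 3 is expected to be a step that the limit leaves unreadable from compound 1 to compound 3, nothing beyond the usual scatter. Compound 3 is therefore estimated at 60000 nM, within a range from 20000 nM to 200000 nM, and it is expected that this assay may again report only a limit.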

Compound 3, half-maximal inhibitory concentration: 23200 nM
The estimate for compound 3 lay 2.6-fold (0.41 log units) above the measured number; the range from low to high includes it.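

At this place on the chain, in this assay, (2-methyl-5-nitro-1H-imidazol-1-yl)methyl in place of 2-nitro-1H-imidazol-1-yl gives an at least 2.1-fold lower number from compound 1 to compound 3 (0.33 log units; beyond the scatter). This is the only step shown that changes one place alone, so it ties a measurable gain to this part of the molecule while the rest of the structure stays the same. That size is only a floor, because compound 1 has a limit and not a number: the limit of > 50000 nM in this assay, at which 1 of the 3 values shown sits.

The change alters several things at once, so the compounds shown do not separate the methyl group, the place of the nitro group on the ring and the extra chain carbon. Also open, on these data alone, is how an amine in place of the nitro group, or a longer chain, would read here.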